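The source may report more compounds than this note shows. Statements on the series, on what has been measured and on what is new or still open speak of the compounds shown alone.

Measured in a functional assay on Vero cells (Chlorocebus sabaeus) for cytotoxicity (on this read-out higher numbers stand for weaker inhibition and lower numbers for stronger inhibition), each value a limit:
- Compound 1 `Nc1ccn([C@H]2CC(F)(F)[C@H](CO)O2)c(=O)n1`: > 100000 nM
- Compound 2 `Cc1cn([C@@H]2CC(F)(F)[C@H](CO)O2)c(=O)nc1O`: > 100000 nM
- Compound 3 `O=c1nc(O)ccn1[C@@H]1CC(F)(F)[C@H](CO)O1`: > 100000 nM

Compound 3 stands only at a limit, > 100000 nM, and not at a true number. The whole set looks the same: the limit of > 100000 nM in this assay, at which 3 of the 3 values shown sit. Compound 4 `O=c1nc(O)ccn1[C@H]1CC(F)(F)[C@H](CO)O1` keeps every atom and bond, and the change is the two compounds have the same atoms and bonds and differ only in configuration as drawn: 1 of 2 stereo elements differ; a stereocentre at a saturated ring carbon is drawn S in compound 3 and R in compound 4: a stereocentre at a saturated ring carbon is drawn S in compound 3 and R in compound 4. Within the data shown here, the only measured step, a step that the two limits leave unreadable from compound 2 to compound 3, concerns another change and gives no size to draw on. With every measured value at the limit of > 100000 nM in this assay, at which 3 of the 3 values shown sit, no step beyond the scatter is expected in this assay, and the expected outcome is another limit. The expected step is a number no higher from compound 3 to compound 4 (the limit leaves the size open). The estimate for compound 4 is 100000 nM, within 40000 nM to 200000 nM.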

Compound 4, half-maximal inhibitory concentration: > 100000 nM
Compound 4 ended at the assay's limit; the forecaster's own chance of this, stated with the estimate: 90%; the middle value sits exactly at the limit.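

No step can be read from compound 3 or from compound 1 to compound 4, since all of them stand at a limit rather than at a true number: the limit of > 100000 nM in this assay, at which 4 of the 4 values shown sit.

The compounds shown leave open at what concentration, if any, they would reach half-maximal inhibition in this assay, and whether configuration matters there.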